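The source may report more compounds than this note shows. Statements on the series, on what has been measured and on what is new or still open speak of the compounds shown alone.

Measured so far in a functional assay on COLO 205 cells (Homo sapiens) for antiproliferative activity, read by MTT assay; a higher number here means a weaker inhibitor, a lower number a stronger inhibitor:
compound 1 `COc1ccc2nc(N(Cc3cc(-c4ccc(Br)cc4)no3)c3nc4ccc(F)cc4s3)sc2c1` gives 7000 nM
compound 2 `COc1ccc2nc(N(Cc3cc(-c4ccccc4F)no3)c3nc4ccc(F)cc4s3)sc2c1` gives 13400 nM
compound 3 `Brc1ccc(-c2cc(CN(c3ncccn3)c3nc4ccccc4s3)on2)cc1` gives 8820 nM

Compounds 1 and 2 share a core; compound 3 carries a different one, and the difference between the two cores is not broken down here. Compound 3 sits nearest compound 1 and furthest from compound 2, both gaps within the scatter.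

For the measured compounds named here, the one counted change is 2-fluorophenyl in place of 4-bromophenyl on an aromatic carbon. The step it made was a 1.9-fold higher number from compound 1 to compound 2 (0.28 log units; within the scatter), so on the core of compound 1 the exchange left the number essentially where it was.

Compound 4 `Fc1ccccc1-c1cc(CN(c2ncccn2)c2nc3ccccc3s2)on1` is not yet measured. It differs from compound 3 by 2-fluorophenyl in place of 4-bromophenyl on an aromatic carbon, which is the same change as that from compound 1 to compound 2, made at the same place and on the same ring. Given that the only precedent is a 1.9-fold higher number from compound 1 to compound 2 (0.28 log units; within the scatter), the expectation for compound 4 is a step of about a 1.7-fold higher number from compound 3 to compound 4 (0.23 log units; within the scatter), again within the scatter. Going by the values given here, compound 4 is therefore estimated at 15000 nM in this assay, with a range from 7000 nM to 35000 nM, resting only on the one precedent, since there is no measured step on the core of compound 3 itself.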

Compound 4, half-maximal inhibitory concentration: 13200 nM
Compound 4: the middle estimate sits 1.1-fold (0.06 log units) above what was measured, and the stated range covers the measured number.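

On the core of compound 3 in this assay, 2-fluorophenyl in place of 4-bromophenyl gives a 1.5-fold higher number from compound 3 to compound 4 (0.18 log units; within the scatter), so here too the exchange leaves the number essentially where it was. The two cores agree on this change: the same change on two cores in this assay, a 1.9-fold higher number (0.28 log units; within the scatter) from compound 1 to compound 2 and a 1.5-fold higher number (0.18 log units; within the scatter) from compound 3 to compound 4, 1.3-fold (0.11 log units) apart, within the scatter of two such steps. This shows that the exchange carries over between these two cores without a step beyond the scatter, but it does not show that either group is better than the other, and two cores are too few to say how the change would behave on a third.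

The compounds shown cover only these two halogen-bearing phenyl groups at this place, so the effect of an amine, a carboxylic acid or a longer alkyl chain on that phenyl ring remains open. For the compounds shown here, also open is what each part of the difference between the two cores contributes, as no pair here differs in only one part of the core.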